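This account rests on a few compounds, and the source may have more. Where it says the series, first, only, none or still open, it means among the compounds named here.

In a functional assay on MCF7 cells (Homo sapiens) for inhibition, read by MTT assay, with a stated time of 5 days (a higher number here means a weaker inhibitor, a lower number a stronger inhibitor), compound 1 (`Cc1cc(Nc2nc(NCc3ccccc3Cl)nc3[nH]ncc23)n[nH]1`) gives 4130 nM while compound 2 (`Cc1cc(Nc2nc(NCc3ccc(Cl)cc3)nc3[nH]ncc23)n[nH]1`) gives 860 nM and compound 3 (`Cc1cc(Nc2nc(NCc3ccc(F)cc3F)nc3[nH]ncc23)n[nH]1`) gives 670 nM as its reading. Compound 3 thus stands level with compound 2, and both lie clearly under compound 1. These three differ only in the substituted phenyl group on a saturated chain carbon. The changes there give a 4.8-fold lower number from compound 1 to compound 2 (0.68 log units; beyond the scatter) and a 6.2-fold lower number from compound 1 to compound 3 (0.79 log units; beyond the scatter) as modest steps, and a 1.3-fold lower number from compound 2 to compound 3 (0.11 log units; within the scatter) within the scatter.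

Compound 4 (`Cc1cc(Nc2nc(NCc3ccc(F)cc3F)nc3c2cnn3C2CCOCC2)n[nH]1`) keeps the 2,4-difluorophenyl group of compound 3 but carries oxan-4-yl in place of hydrogen on an aromatic nitrogen. For the measured compounds named here, none of the measured steps touches that nitrogen, so they offer only a sense of scale and say nothing about direction. In this assay the expected outcome is therefore no step beyond the scatter, estimated as a 1.2-fold higher number from compound 3 to compound 4 (0.08 log units; within the scatter) with little confidence in its direction. The value expected for compound 4 is 800 nM (estimated range 200 nM to 3200 nM).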

Compound 4, half-maximal inhibitory concentration: 360 nM
Compound 4: the middle estimate sits 2.2-fold (0.35 log units) above what was measured; low and high end bracket the measured number.
By their numbers in this assay, from the lowest: compounds 4, 3 and 2 (each within the scatter of the next, the first and the last beyond it); then compound 1.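

Until now, every compound carried only hydrogen on this aromatic nitrogen, so nothing showed whether the position could take a larger group. Compound 4 shows that it can here: placing oxan-4-yl, a six-membered non-aromatic ring, on that nitrogen gives a 1.9-fold lower number from compound 3 to compound 4 (0.27 log units; within the scatter) in this assay, so the reading holds within the normal spread of repeat measurements. At least with the 2,4-difluorophenyl group in place, this sizeable addition costs nothing measurable in this test, though no data here explain why the reading holds.

From the compounds shown here alone, it remains open whether a small methyl group, or a cyclohexyl ring lacking the ring oxygen, would read the same on this nitrogen. Also open, going by these compounds, is whether oxan-4-yl would behave this way alongside the 2-chlorophenyl group of compound 1.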